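The compounds below may be only part of what the source reports. "The series", "measured", "known", "first", "only" and "open" are said of these compounds alone.

Measured compounds and their numbers:
- compound 1, `CCOC(=O)C1=C(C)N/C(=C/c2cc(C)n(-c3ccc(Cl)cc3)c2C)C1=O`: 100000 nM
- compound 2, `CCOC(=O)C1=C(C)N/C(=C/c2cc(C)n(-c3cccc(O)c3)c2C)C1=O`: 69000 nM
- compound 3, `CCOC(=O)C1=C(C)N/C(=C/c2cc(C)n(C)c2C)C1=O`: 310000 nM

The three compounds share one core and differ only in the group on the aromatic nitrogen. In an ADME assay on L6 cells (Rattus norvegicus) for cytotoxicity, read by resazurin assay, with a stated time of 72 h (a higher number here means that more compound is needed for the effect, a lower number that less compound is needed), compound 3, which carries a methyl there, gives the highest number of the three. The change from compound 1 to compound 3 is a 3.1-fold higher number from compound 1 to compound 3 (0.49 log units; beyond the scatter), and that from compound 2 to compound 3 is a 4.5-fold higher number from compound 2 to compound 3 (0.65 log units; beyond the scatter); both are modest steps beyond the scatter. The pair compound 1 and compound 2 shows a 1.4-fold lower number from compound 1 to compound 2 (0.16 log units; within the scatter), within the scatter.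

Compound 4, `CCOC(=O)C1=C(C)N/C(=C/c2cc(C)n(Cc3ccccc3)c2C)C1=O`, has not yet been measured in this assay. Relative to compound 3 the change is phenyl in place of hydrogen on a saturated chain carbon bound to an aromatic nitrogen; read one bond further out, methyl becomes benzyl. The two steps that bear on it are those in which an aryl group on the nitrogen gave way to methyl, each raising the number by a modest amount. Compound 4 puts an aromatic ring back, though now one bond removed from the nitrogen, so a modest step downward from compound 3 is the expectation, roughly the reverse of a 3.1-fold higher number from compound 1 to compound 3 (0.49 log units; beyond the scatter). The step from compound 3 to compound 4 is therefore estimated at a 2.6-fold lower number from compound 3 to compound 4 (0.41 log units; beyond the scatter). For compound 4 the expected value in this assay is 120000 nM, with a range from 50000 nM to 300000 nM.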

Compound 4, half-maximal effective concentration in the L6 assay: 50000 nM
Estimate against measurement, compound 4: 2.4-fold (0.38 log units) above, within the range that was stated.
By their numbers in the L6 assay, from the lowest: compounds 4, 2 and 1 (each within the scatter of the next); then compound 3.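

In the L6 assay compound 4 gives 50000 nM. With a benzyl group on the aromatic nitrogen, the L6 assay shows a 6.2-fold lower number from compound 3 to compound 4 (0.79 log units; beyond the scatter), so an aromatic ring set one bond away from that nitrogen also separates a compound from the methyl compound. Compound 4 is not separated from the two compounds with the ring directly on the nitrogen, as shown by a 1.4-fold lower number from compound 2 to compound 4 (0.14 log units; within the scatter) and by a 2.0-fold lower number from compound 1 to compound 4 (0.30 log units; within the scatter), and across these three compounds the change from 4-chlorophenyl or 3-hydroxyphenyl to benzyl leaves the number within the scatter. No supporting information explains this result. In a physicochemical assay for lipophilicity, read by HPLC, at pH 7.4 (a higher number here means a more lipophilic compound, a lower number a more polar compound), compound 3 gives "not determined" (no result reported) and compound 4 gives "not determined" (no result reported), so no step can be read there.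

The compounds shown leave open whether the aromatic ring itself matters or whether a non-aromatic group on the nitrogen, such as a butyl chain or a cyclohexylmethyl group, would give a similar number. They also leave open how a 2-phenylethyl group, with its longer chain, or a benzyl group carrying an amine or a carboxylic acid would read in the L6 assay.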